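The compounds below may be only part of what the source reports. "The series", "measured", "known", "first", "only" and "open" are said of these compounds alone.

Within the data shown here, compound 2, `COC(=O)/C(=C\c1ccc(OC(=O)c2ccccc2OC)cc1)Sc1ccnc2cc(Cl)ccc12`, is one of two compounds measured in a functional assay on Jurkat E6.1 cells (Homo sapiens) for cytotoxicity, read by MTT assay, with a stated time of 24 h; a higher number here means a weaker inhibitor, a lower number a stronger inhibitor. In this assay compound 2 gives 44700 nM, the highest of the two numbers shown, and its nearest neighbour is compound 1, `COC(=O)/C(=C\c1ccc(OC(=O)c2ccccc2)cc1)Sc1ccnc2cc(Cl)ccc12`, which in this assay gives 35700 nM. The two differ only by a methoxy in place of hydrogen on an aromatic carbon, and the step of a 1.3-fold higher number from compound 1 to compound 2 (0.10 log units; within the scatter) lies within the scatter of the method.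

Compound 3, `COC(=O)/C(=C\c1ccc(OC(=O)c2ccc(OC)c(OC)c2)cc1)Sc1ccnc2cc(Cl)ccc12`, has not yet been measured in this assay. It differs from compound 2 in one place: 3,4-dimethoxyphenyl in place of 2-methoxyphenyl on a carbonyl carbon. Among the measured compounds shown here, the single step already measured, from compound 1 to compound 2, adds a methoxy to the same aromatic ring and changes nothing beyond the scatter. Compound 3 carries two methoxy groups on that ring where compound 2 carries one, so on the evidence available the step of a 1.0-fold higher number from compound 2 to compound 3 (0.00 log units; within the scatter) is expected to stay within the scatter as well. Compound 3 is therefore estimated at 45000 nM, with a range from 22000 nM to 90000 nM.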

Compound 3, half-maximal inhibitory concentration: 8290 nM
Beside the measured number, compound 3's estimate is 5.4-fold (0.73 log units) above it; the whole stated range lies above it.
By their numbers in this assay, from the lowest: compound 3; then compounds 1 and 2 (each within the scatter of the next).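

In this assay, among these compounds, the group on the carbonyl carbon now proves able to move the number, which the single methoxy of compound 2 did not show: 3,4-dimethoxyphenyl in place of 2-methoxyphenyl gives a 5.4-fold lower number from compound 2 to compound 3 (0.73 log units; beyond the scatter) and so lies beyond the scatter. The same group in place of phenyl gives a 4.3-fold lower number from compound 1 to compound 3 (0.63 log units; beyond the scatter) and is also beyond the scatter, so the change holds from both neighbours, although both steps are modest, and compound 3 alone stands apart from the other two. Nothing available bears on what lies behind this difference.

The exchange alters both the number of methoxy groups and where they sit on the ring, and the compounds shown cannot separate the two, since neither a 3-methoxyphenyl nor a 4-methoxyphenyl group appears among them. Going by these compounds, it also remains open whether other groups on that ring, such as an amine, a carboxylic acid or a third methoxy as in 3,4,5-trimethoxyphenyl, would lower the number further, leave it unchanged or raise it.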